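The compounds below may be only part of what the source reports. "The series", "measured", "known", "first", "only" and "open" are said of these compounds alone.

Measured so far:
compound 1, `O=C(Nc1cccc(-n2cc(-c3ccncc3)c(-c3ccc(Cl)c(O)c3)n2)c1)Nc1cccc(C(F)(F)F)c1`: 13800 nM
compound 2, `COc1cc(-c2nn(-c3cccc(NC(=O)Nc4ccc(Cl)c(Cl)c4)c3)cc2-c2ccncc2)ccc1Cl`: 3020 nM

In a functional assay on SK-MEL-5 cells (Homo sapiens) for inhibition, read by sulforhodamine B assay, with a stated time of 48 h (a lower number here means that less compound is tolerated, a higher number that more compound is tolerated), compound 2 gives the lowest of the two numbers; compound 1 stands higher, and the gap between them lies beyond the scatter. Going by the values given here, the two compounds differ in two places at once, so their pair yields no single step that can be read on its own.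

Compound 3, `O=C(Nc1cccc(-n2cc(-c3ccncc3)c(-c3ccc(Cl)c(O)c3)n2)c1)Nc1ccc(Cl)c(Cl)c1`, is not yet measured. Relative to compound 2 the change is hydrogen in place of methyl on an oxygen on an aromatic ring; the rest of the molecule is kept. Compound 3 carries the same hydroxy as compound 1, which in this assay gives 13800 nM, but it also carries the same 3,4-dichlorophenyl as compound 2, so neither measured compound settles the question alone. The step from compound 2 to compound 3 is expected to be small and upward, a 1.7-fold higher number from compound 2 to compound 3 (0.22 log units; within the scatter), not far beyond the scatter. Compound 3 is therefore estimated at 5000 nM, with a range from 2000 nM to 14000 nM.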

Compound 3, concentration lethal to 50% of the cells: 2350 nM
The estimate for compound 3 lay 2.1-fold (0.33 log units) above the measured number, within the range that was stated.
By their numbers in this assay, from the lowest: compounds 3 and 2 (each within the scatter of the next); then compound 1.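

In this assay the step of a 1.3-fold lower number from compound 2 to compound 3 (0.11 log units; within the scatter) stays within the scatter, so with 3,4-dichlorophenyl kept on the amide-type nitrogen, methoxy and hydroxy on the aromatic ring are not separated. Going by these compounds alone, with the 4-chloro-3-hydroxyphenyl kept, 3,4-dichlorophenyl in place of 3-(trifluoromethyl)phenyl gives a 5.9-fold lower number from compound 1 to compound 3 (0.77 log units; beyond the scatter) and lies beyond the scatter, the first change in a single place to separate two compounds in this assay. Nothing on hand explains either step.

Open, going by these compounds, is whether an amine or an ethoxy group in place of the hydroxy would stay level with compound 3 or move away from it. Also open, on these data alone, is whether methoxy to hydroxy reads the same with 3-(trifluoromethyl)phenyl on the amide-type nitrogen.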